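Moving a methyl on the aryl ketone: cytotoxicity estimate

The compounds below may be only part of what the source reports. "The series", "measured", "known", "first", "only" and "open" are said of these compounds alone.

Measured compounds:
- compound 1, `Cc1ccc(C(=O)c2cc(Cl)ccc2Oc2ccnc(Nc3ccc(C#N)cc3)n2)cc1`: 1710 nM
- compound 2, `Cc1cc(C)cc(C(=O)c2cc(Cl)ccc2Oc2ccnc(Nc3ccc(C#N)cc3)n2)c1`: 28800 nM

Both compounds were tested in an ADME assay on MT4 cells (Homo sapiens) for cytotoxicity, read by MTT assay, with a stated time of 5 days; on this read-out higher numbers stand for lower toxicity in this test and lower numbers for higher toxicity in this test. Compound 2 holds the higher of the two numbers, the gap being a 17-fold higher number from compound 1 to compound 2 (1.23 log units; beyond the scatter), so the 3,5-dimethylphenyl compound is clearly less toxic in this test than the 4-methylphenyl one.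

Compound 3, `Cc1ccccc1C(=O)c1cc(Cl)ccc1Oc1ccnc(Nc2ccc(C#N)cc2)n1`, is the next step from compound 2: 2-methylphenyl in place of 3,5-dimethylphenyl on a carbonyl carbon. Within the data shown here, only one measured step bears on this change, the step from the 4-methylphenyl to the 3,5-dimethylphenyl ketone, and it was large. It shows that the number of methyl groups and where they sit on this ring can shift the read-out strongly, but it says nothing direct about a single methyl in the 2-position. Because compound 1 with a single methyl gave 1710 nM, a single methyl in a different place may well pull the number back down towards it, though by how much cannot be read from the data.

For compound 3 a step of a 3.6-fold lower number from compound 2 to compound 3 (0.56 log units; beyond the scatter) is therefore expected. The estimated value for compound 3 in this assay is 8000 nM, with a range from 2000 nM to 35000 nM.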

Compound 3, half-maximal cytotoxic concentration: 28800 nM
For compound 3 the middle estimate is 3.6-fold (0.56 log units) below the measured one; the range from low to high includes it.
By their numbers in this assay, from the lowest: compound 1; then compounds 2 and 3 (each within the scatter of the next).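

In this assay, the change reads as no change at the digits printed from compound 2 to compound 3 (within the scatter), so the 2-methylphenyl ketone cannot be told apart from the 3,5-dimethylphenyl ketone in this test, even though it carries one methyl group fewer. The other comparison, a 17-fold higher number from compound 1 to compound 3 (1.23 log units; beyond the scatter), sets two ketones with a single methyl group against each other and shows that moving that methyl from the 4-methylphenyl arrangement to the 2-methylphenyl arrangement is enough for a large shift, so among these three compounds the number of methyl groups alone does not decide the read-out, and compound 1 is the one that stands apart. Nothing available here explains why these ring patterns give these numbers.

The compounds shown leave open how a plain phenyl ring or a 3-methylphenyl ring on the carbonyl carbon would read in this assay, which would help show whether compound 1 is the exception or part of a wider trend. They also leave open what happens when the methyl is replaced by a different group, such as a methoxy group, a chlorine atom or an amine.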